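The source may report more compounds than this note shows. Statements on the series, on what has been measured and on what is new or still open speak of the compounds shown alone.

Measured compounds in an assay for inhibition of protein disulfide-isomerase (Homo sapiens), with a stated time of 1 h; on this read-out higher numbers stand for weaker inhibition and lower numbers for stronger inhibition:
compound 1 `Cc1ccnc(NC(c2ccc3cccnc3c2O)c2c(F)cccc2Cl)c1`, reported as a limit of the assay, > 40000 nM.
compound 2 `Cc1ccnc(NC(c2ccccc2C)c2ccc3cccnc3c2O)c1`, reported as a limit of the assay, > 40000 nM.

Compound 2 stands only at a limit in this assay, and the other value shown is a limit as well (the limit of > 40000 nM in this assay, at which 2 of the 2 values shown sit). The step that the two limits leave unreadable from compound 1 to compound 2 is accordingly not readable. Compound 3 `Cc1ccnc(NC(c2cccc(F)c2)c2ccc3cccnc3c2O)c1` differs from compound 2 by 3-fluorophenyl in place of 2-methylphenyl on a saturated chain carbon bound to an aromatic carbon and a nitrogen on an aromatic ring. Within the data shown here, no measured step bears readably on this change, and no step beyond the scatter is expected in either direction in this assay. The step that the limit leaves unreadable from compound 2 to compound 3 is an estimate only. Compound 3 is expected near 60000 nM, range 15000 nM to 300000 nM, most likely reported as a limit again.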

Compound 3, half-maximal inhibitory concentration: 350 nM
Compound 3: middle estimate off by 170-fold (2.23 log units), on the high side; measured number outside the range, below it.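

In this assay, the group on the saturated chain carbon can decide whether a readable number appears at all. With the shared core unchanged, 3-fluorophenyl in place of 2-methylphenyl gives an at least 110-fold lower number from compound 2 to compound 3 (2.05 log units; beyond the scatter), and 3-fluorophenyl in place of 2-chloro-6-fluorophenyl gives an at least 110-fold lower number from compound 1 to compound 3 (2.05 log units; beyond the scatter). These sizes are minimum values, and the step between compound 1 and compound 2 cannot be read, because both compounds sit at a limit: the limit of > 40000 nM in this assay, at which 2 of the 3 values shown sit.

From the compounds shown here alone, whether the gain depends on the fluorine remains open. An unsubstituted phenyl or a 3-methoxyphenyl at this place would bear on that question.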